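A few compounds are considered here, and "the series" means these few. Any claim that something is new, unique, unknown or untested is made for them only; others in the source may bear on it.

Compound 2 `Cc1ccc(C)c(NC(=O)Nc2nc(Sc3c[nH]c4ccccc34)cc(N3CCCCC3)n2)c1` and compound 1 `COc1ccc(NC(=O)Nc2nc(Sc3c[nH]c4ccccc34)cc(N3CCCCC3)n2)cc1` share one core and differ in a single place: 4-methoxyphenyl in place of 2,5-dimethylphenyl on an amide-type nitrogen. In a functional assay on MDA-MB-231 cells (Homo sapiens) for inhibition, with a stated time of 72 h (a higher number here means a weaker inhibitor, a lower number a stronger inhibitor), compound 2 gives 5940 nM, and compound 1 gives 7260 nM; the step between them is a 1.2-fold higher number from compound 2 to compound 1 (0.09 log units; within the scatter). Compound 3 `Cc1ccc(C)c(NC(=O)Nc2nc(Sc3c[nH]c4ccccc34)cc(N3CCN(Cc4ccccc4)CC3)n2)c1` carries a different core, and the difference between the two cores is not broken down here. In this assay compound 3 gives 19000 nM, the highest of the three numbers seen so far. Compound 4 `COc1ccc(NC(=O)Nc2nc(Sc3c[nH]c4ccccc34)cc(N3CCN(Cc4ccccc4)CC3)n2)cc1` has not yet been measured; it stands to compound 3 exactly as compound 1 stands to compound 2, with the same change at the same place: 4-methoxyphenyl in place of 2,5-dimethylphenyl on an amide-type nitrogen. Given that precedent, the step is expected to be small, roughly a 1.2-fold higher number from compound 3 to compound 4 (0.08 log units; within the scatter), because the earlier step was a 1.2-fold higher number from compound 2 to compound 1 (0.09 log units; within the scatter). Compound 4 is therefore estimated at 23000 nM, most likely between 11000 nM and 48000 nM.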

Compound 4, half-maximal inhibitory concentration: 8920 nM
The estimate for compound 4 lay 2.6-fold (0.41 log units) above the measured number, outside the stated range (below it).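

In this assay replacing 2,5-dimethylphenyl with 4-methoxyphenyl on the amide-type nitrogen gives a 2.1-fold lower number from compound 3 to compound 4 (0.33 log units; beyond the scatter), whereas the same change on the core of compound 2 gave a step within the scatter. Set side by side, the two steps cannot be told apart: the same change on two cores in this assay, a 1.2-fold higher number (0.09 log units; within the scatter) from compound 2 to compound 1 and a 2.1-fold lower number (0.33 log units; beyond the scatter) from compound 3 to compound 4, 2.6-fold (0.42 log units) apart, within the scatter of two such steps. The pair therefore gives no firm sign that the core alters the effect of this change, but two steps alone do not show that the effect carries over unchanged.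

The compounds shown leave open how a phenyl bearing a carboxylic acid or an amine would behave on the amide-type nitrogen. They also leave open whether the change would give a similar step on a core carrying a morpholine.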